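Shifting a Chlorine on the Benzyl Arm of Compound 3

The source may report more compounds than this note shows. Statements on the series, on what has been measured and on what is new or still open speak of the compounds shown alone.

Three compounds have been measured in a functional assay on MCF7 cells (Homo sapiens) for inhibition, read by MTT assay, with a stated time of 72 h; on this read-out higher numbers stand for weaker inhibition and lower numbers for stronger inhibition:

Compound 1 `CC(C)(C)OC(=O)N1CCN(C(=S)SCc2cn(-c3ccccc3F)nn2)CC1` gives 89600 nM
Compound 2 `COc1ccc(Cn2cc(CSC(=S)N3CCN(C(=O)OC(C)(C)C)CC3)nn2)cc1` gives 4960 nM
Compound 3 `CC(C)(C)OC(=O)N1CCN(C(=S)SCc2cn(Cc3ccc(Cl)c(Cl)c3)nn2)CC1` gives 19100 nM

Compound 3 stands second highest of the three. Its nearest neighbour is compound 2, a modest step: a 3.9-fold higher number from compound 2 to compound 3 (0.59 log units; beyond the scatter). Its furthest is compound 1: a 4.7-fold lower number from compound 1 to compound 3 (0.67 log units; beyond the scatter).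

Compound 4 `CC(C)(C)OC(=O)N1CCN(C(=S)SCc2cn(Cc3ccccc3Cl)nn2)CC1` differs from compound 3 in one place: 2-chlorophenyl in place of 3,4-dichlorophenyl on a saturated chain carbon bound to an aromatic nitrogen. Within the data shown here, the only measured step at this same place is a 3.9-fold higher number from compound 2 to compound 3 (0.59 log units; beyond the scatter), and it swapped groups far more different from each other than these two. The other steps, an 18-fold lower number from compound 1 to compound 2 (1.26 log units; beyond the scatter) and a 4.7-fold lower number from compound 1 to compound 3 (0.67 log units; beyond the scatter), change another part of the molecule, so they say little here. A step within the scatter is therefore expected: a 1.1-fold lower number from compound 3 to compound 4 (0.05 log units; within the scatter). Compound 4 is estimated at 17000 nM, between 5000 nM and 55000 nM.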

Compound 4, half-maximal inhibitory concentration: 6090 nM
For compound 4 the middle estimate is 2.8-fold (0.45 log units) above the measured one; low and high end bracket the measured number.
By their numbers in this assay, from the lowest: compounds 2 and 4 (each within the scatter of the next); then compound 3; then compound 1.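

Trading 3,4-dichlorobenzyl for 2-chlorobenzyl is a small edit, yet it still moves the number, with a 3.1-fold lower number from compound 3 to compound 4 (0.50 log units; beyond the scatter). The change also leaves no order between this arm and 4-methoxybenzyl, with a 1.2-fold higher number from compound 2 to compound 4 (0.09 log units; within the scatter), and 2-chlorobenzyl stays well clear of 2-fluorophenyl, with a 15-fold lower number from compound 1 to compound 4 (1.17 log units; beyond the scatter). Nothing available explains these steps.

Still open, as far as these compounds go, is whether losing one chlorine or changing its place matters more, and a 3-chlorobenzyl or 4-chlorobenzyl arm would separate the two. A plain benzyl arm would show what any chlorine adds.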